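The source may hold more compounds than are shown below. What is called first, only, known or untested is meant among the compounds shown, and "the series" means these compounds.

Measured compounds:
- compound 1, `Cc1ccc2[nH]c(-c3cn(-c4ccccc4)nc3-c3ccccc3)nc2c1`, 6560 nM
- compound 2, `Cc1ccc2[nH]c(-c3cn(-c4ccccc4)nc3-c3ccc(Cl)cc3)nc2c1`, 5360 nM
- compound 3, `COc1ccc(-c2nn(-c3ccccc3)cc2-c2nc3cc(Cl)ccc3[nH]2)cc1`, 1290 nM

All three were run in a functional assay on HeLa cells (Homo sapiens) for antiproliferative activity, read by MTT assay, with a stated time of 48 h; on this read-out lower numbers stand for stronger inhibition and higher numbers for weaker inhibition. Compound 1 and compound 2 share a core and differ in one place: chloro in place of hydrogen on an aromatic carbon. The step of a 1.2-fold lower number from compound 1 to compound 2 (0.09 log units; within the scatter) is small, so the two numbers cannot be ordered. Compound 3 gives the lowest of the three numbers; the difference between its core and that of compound 1 is not broken down here, and the gaps from compound 2 and from compound 1 to compound 3 lie beyond the scatter.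

Compound 4, `COc1ccc(-c2nn(-c3ccccc3)cc2-c2nc3cc(Cl)c(Cl)cc3[nH]2)cc1`, is not yet measured. It differs from compound 3 in one place: chloro in place of hydrogen on an aromatic carbon. Within the data shown here, this is the same kind of change as the one from compound 1 to compound 2, but not the same: there the entering chloro sat on a six-membered aromatic ring of carbon only, para to a large group; here it sits on a ring that is part of a fused or bridged system of two rings, ortho to a chloro group, meta to a fused ring and para to a fused ring.

Among the measured compounds shown here, the only measured instance of this kind of change, a 1.2-fold lower number from compound 1 to compound 2 (0.09 log units; within the scatter), stayed within the scatter, so the step expected for a 1.2-fold lower number from compound 3 to compound 4 (0.07 log units; within the scatter) is likewise small, with no basis for a larger move in either direction. Compound 4 is therefore estimated at 1100 nM, expected to fall between 400 nM and 3200 nM.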

Compound 4, half-maximal inhibitory concentration: 6600 nM
For compound 4 the middle estimate is 6.0-fold (0.78 log units) below the measured one; the measured number lies above the stated range.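

In this assay, chloro in place of hydrogen on an aromatic carbon does not carry over from one core to another as a fixed step: the same change on two cores in this assay, a 1.2-fold lower number (0.09 log units; within the scatter) from compound 1 to compound 2 and a 5.1-fold higher number (0.71 log units; beyond the scatter) from compound 3 to compound 4, 6.3-fold (0.80 log units) apart, beyond the scatter of two such steps
On the core of compound 3, the entering chloro sits on a ring that is part of a fused or bridged system of two rings, ortho to a chloro group, and the step (a 5.1-fold higher number from compound 3 to compound 4 (0.71 log units; beyond the scatter)) moves towards weaker inhibition, so the small step seen on the first core cannot be used as a guide for this site. These two instances do not show which feature is responsible, since the two pairs differ at once in the ring carrying the chloro, its surroundings and the rest of the core, and two steps give no general rule for the series.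

Still open, as far as these compounds go, is whether a fluoro, a nitrile or an amine in the same place would give a step of similar size to that of the chloro. Also open, from the compounds shown here alone, is whether the same step would appear on the core of compound 3 with the methoxy replaced by another group, such as a carboxylic acid or a longer alkoxy chain.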